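The source may report more compounds than this note shows. Statements on the series, on what has been measured and on what is new or still open speak of the compounds shown alone.

Of the compounds shown here, two in this set have been tested in an ADME assay on Huh-7 cells (Homo sapiens) for cytotoxicity, read by MTT assay, with a stated time of 48 h; a lower number here means a stronger inhibitor, a higher number a weaker inhibitor. Compound 1, `O=[N+]([O-])c1cc(COc2nnnn2-c2ccc(Cl)c(Cl)c2)cc([N+](=O)[O-])c1`, gives > 30000 nM, which is a limit of the measurement rather than a number. Compound 2, `O=[N+]([O-])c1cc(C[Se]c2nnnn2Cc2ccccc2)cc([N+](=O)[O-])c1`, gives > 30000 nM in this assay, again a limit and not a number. Both results sit at the limit of > 30000 nM in this assay, at which 2 of the 2 values shown sit, so compound 2 stands at that limit together with compound 1, and nothing separates the two. Compound 3, `COc1ccc(-n2nnnc2[Se]Cc2cc([N+](=O)[O-])cc([N+](=O)[O-])c2)cc1`, has not yet been measured. It differs from compound 2 by 4-methoxyphenyl in place of benzyl on an aromatic nitrogen. For the measured compounds named here, no step between measured compounds is available here, so the size of this change can only be guessed. The expected change is a step that the limit leaves unreadable from compound 2 to compound 3, that is, none beyond the usual scatter. In this assay compound 3 is therefore estimated at 40000 nM, with a range from 15000 nM to 100000 nM, and most likely only a limit will again be reported.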

Compound 3, half-maximal inhibitory concentration: > 30000 nM
Compound 3 gave a limit, no number; the forecaster's own chance of this, stated with the estimate: 80%; the middle value does not contradict the limit.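

In this assay, for the compounds shown here, compound 3 gives only a limit, as compound 2 does, so no step between compound 2 and compound 3 can be read. How 4-methoxyphenyl and benzyl compare on that aromatic nitrogen stays open, as do any differences among compounds 1, 2 and 3, since all three share one limit: the limit of > 30000 nM in this assay, at which 3 of the 3 values shown sit.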